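Swapping a Nitrile Chain for a Fluorinated Ring

A few compounds are considered here, and "the series" means these few. Any claim that something is new, unique, unknown or untested is made for them only; others in the source may bear on it.

Compound 1 (`Cc1cc(C)c(S(=O)(=O)N2CCC(N3CCC(CCC#N)CC3)CC2)c(C)c1`) > 5000 nM
Compound 2 (`Cc1nc(Cl)sc1S(=O)(=O)N1CCC(N2CCC(C)CC2)CC1`) > 10000 nM
Compound 3 (`COc1ccc(S(=O)(=O)N2CCC(N3CCC(C)CC3)CC2)cc1OC`) > 5000 nM

These results come from an ADME assay on HCT-116 cells (Homo sapiens) for cytotoxicity, read by CellTiter-Glo, with a stated time of 72 h (on this read-out lower numbers stand for stronger inhibition and higher numbers for weaker inhibition), and each one is a limit, not a number. Compound 1 stands at the limit of > 5000 nM in this assay, at which 2 of the 3 values shown sit, and so has no exact value. Compound 4 (`Cc1cc(C)c(S(=O)(=O)N2CCC(N3CCC(Cc4ccccc4F)CC3)CC2)c(C)c1`) keeps the core of compound 1 but changes one group (2-fluorophenyl in place of cyanomethyl on a saturated chain carbon bound to a saturated ring carbon) with 2-fluorophenyl in place of cyanomethyl on a saturated chain carbon bound to a saturated ring carbon. Cut one bond further out, the same change reads 2-cyanoethyl to 2-fluorobenzyl.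

Going by the values given here, no two measured compounds differ in only one place, so these data show no step of this kind. The expectation therefore rests on compound 1 and its limit of > 5000 nM as the starting point. In this assay the expected change (a step that the limit leaves unreadable from compound 1 to compound 4) is no larger than the usual scatter, with neither direction favoured. For compound 4 the estimated value is 6000 nM within an expected range of 2500 nM to 15000 nM and a limit is the likeliest outcome.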

Compound 4, half-maximal inhibitory concentration: > 5000 nM
Compound 4: a limit, no number; the forecaster's own chance of this, stated with the estimate: 80%; the middle value lies beyond the limit too.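

Compound 1 and compound 4 each give a limit rather than a number, so no step can be read from compound 1 to compound 4. On these data alone, whether replacing cyanomethyl with 2-fluorophenyl changes the result in this assay at all, and in which direction, stays open.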